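From a thiazolyl amide to a pyridinyl amide

The source may hold more compounds than are shown below. What is called first, only, known or untested is meant among the compounds shown, and "the series" means these compounds.

In a functional assay on DU-145 cells (Homo sapiens) for antiproliferative activity, read by sulforhodamine B assay, with a stated time of 3 days (a lower number here means a stronger inhibitor of growth, a higher number a weaker inhibitor of growth), compound 2 (`O=C(Nc1nccs1)c1cccc(Nc2ncc(F)c(Nc3ccc(F)cc3)n2)c1`) is reported as > 10000 nM, which is a limit of the assay and not a number. This is the limit of > 10000 nM in this assay, at which 1 of the 3 values shown sits. Compound 4 (`O=C(Nc1cccc(Nc2ncc(F)c(Nc3ccc(F)cc3)n2)c1)c1ccncc1`) has not yet been measured. It differs from compound 2 by ((pyridin-4-yl)carbonyl)amino in place of (1,3-thiazol-2-yl)carbamoyl, on an aromatic carbon of a six-membered aromatic ring of carbon only, meta to a large group: ((pyridin-4-yl)carbonyl)amino in place of (1,3-thiazol-2-yl)carbamoyl on an aromatic carbon. The only measured step among these compounds is a step that the limit leaves unreadable from compound 1 to compound 2, so it offers no size to carry over. Compound 1 (`O=C(Nc1ccccn1)c1cccc(Nc2ncc(F)c(Nc3ccc(F)cc3)n2)c1`) gives 15100 nM in this assay. Compound 4 carries its amide the same way round as compound 3 (`O=C(Nc1cccc(Nc2ncc(F)c(Nc3ccc(F)cc3)n2)c1)c1cccc([N+](=O)[O-])c1`), and compound 3 gives 12600 nM. These two values lie within the usual scatter of each other. Resting on compound 1 with 15100 nM and compound 3 with 12600 nM, no step beyond the scatter is expected in this assay. A report of compound 4 as a limit only would be no surprise. The expected step is a step that the limit leaves unreadable from compound 2 to compound 4. For compound 4 the estimated value is 12000 nM, with an expected range from 5000 nM to 30000 nM.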

Compound 4, concentration for 50% growth inhibition: 4330 nM
Compound 4: the middle estimate sits 2.8-fold (0.44 log units) above what was measured, outside the stated range (below it).
By their numbers in this assay, from the lowest: compound 4; then compounds 3 and 1 (each within the scatter of the next).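

In this assay, within the data shown here, compound 4 gives the first readable change at this position: with the amide the same way round, pyridin-4-yl in place of 3-nitrophenyl on the carbonyl carbon gives a 2.9-fold lower number from compound 3 to compound 4 (0.46 log units; beyond the scatter). The direction of the amide alone therefore does not set the number, since compound 3 shares that direction with compound 4, and the group on the carbonyl carbon also counts; against the amides turned the other way, the change gives a 3.5-fold lower number from compound 1 to compound 4 (0.54 log units; beyond the scatter) and an at least 2.3-fold lower number from compound 2 to compound 4 (0.36 log units; beyond the scatter). The second of these steps starts from compound 2, which stands only at a limit of the assay and not at a number, so its true size stays unknown: the limit of > 10000 nM in this assay, at which 1 of the 4 values shown sits.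

The compounds shown leave open whether the nitrogen of the pyridin-4-yl ring matters at all, or whether a plain phenyl or a pyridin-3-yl on the same carbonyl carbon would read the same. They also leave open how that ring would read in this assay if it carried an amine or a carboxylic acid.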